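Removing the nitrile from a symmetric choline kinase alpha binder

The compounds below may be only part of what the source reports. "The series", "measured", "known", "first", "only" and "open" are said of these compounds alone.

Measured so far:
- compound 1, `CN1CCCN(Cc2ccc(-c3ccccc3)cc2)CC1`: 3700 nM
- compound 2, `CN1CCCN(Cc2ccc(-c3ccc(CN4CCCN(C)CC4)cc3C#N)cc2)CC1`: 10 nM

Both compounds were tested in an assay on isolated protein for binding affinity to choline kinase alpha (Homo sapiens), read by surface plasmon resonance; a lower number here means tighter binding, a higher number weaker binding. Compound 1 carries a single (4-methyl-1,4-diazepan-1-yl)methyl arm on its biphenyl-type core and gives 3700 nM in this assay. Compound 2 carries two such arms, one on each ring, together with a cyano group, and gives 10 nM in this assay, the lower of the two numbers, separated from compound 1 by a gap that lies well beyond the scatter. Whether that gain comes from the second arm, from the cyano group, or from both together cannot be read from these two numbers alone.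

Compound 3, `CN1CCCN(Cc2ccc(-c3ccc(CN4CCCN(C)CC4)cc3)cc2)CC1`, keeps both arms but differs from compound 2 in one place: hydrogen in place of cyano on an aromatic carbon. For the measured compounds named here, since no measured pair isolates the cyano group, its contribution is unknown. The step is expected to be small, probably a modest loss of affinity, with no change beyond the scatter also plausible: a 2.5-fold higher number from compound 2 to compound 3 (0.40 log units; beyond the scatter). In this assay compound 3 is thus estimated at 25 nM, likely between 8 nM and 80 nM.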

Compound 3, dissociation constant: 382 nM
Compound 3: the middle estimate sits 15-fold (1.18 log units) below what was measured; the measured number lies above the stated range.
By their numbers in this assay, from the lowest: compound 2; then compound 3; then compound 1.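

In this assay, the cyano group on this aromatic carbon, ortho to a large group, proves to be far from a minor detail: putting hydrogen in its place gives a 38-fold higher number from compound 2 to compound 3 (1.58 log units; beyond the scatter) and removes most of the affinity of compound 2. The second arm now has its own measure as well: (4-methyl-1,4-diazepan-1-yl)methyl in place of hydrogen on an aromatic carbon gives a 9.7-fold lower number from compound 1 to compound 3 (0.99 log units; beyond the scatter), so the wide gap between compound 1 and compound 2 divides into two steps, with the cyano step the larger of them. Nothing shown here gives a reason for the size of either step.

What the compounds shown leave open is whether the nitrile is unusual in doing this, since a chlorine atom, a methyl group or a primary amide on the same aromatic carbon would put that to the test. Also open, as far as these compounds go, is whether a nitrile on the core of compound 1, with its single arm, would bring a gain as large as the one it brings alongside two arms.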